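Chloro on Compound 2, Which Sits at a Limit

This account rests on a few compounds, and the source may have more. Where it says the series, first, only, none or still open, it means among the compounds named here.

In a functional assay on UACC-62 cells (Homo sapiens) (a lower number here means a stronger inhibitor of growth, a higher number a weaker inhibitor of growth), compound 1 `O=S(=O)(/C=C/c1ccc(F)cc1)Cc1ccc(Nc2ncnc3ccccc23)cc1` gives 5000 nM. Compound 2 `O=S(=O)(/C=C/c1ccc(F)cc1F)Cc1ccc(Nc2ncnc3ccccc23)cc1` has no exact number: its > 100000 nM is a limit of the assay. Among the measured compounds shown here, the only measured step, an at least 20-fold higher number from compound 1 to compound 2 (1.30 log units; beyond the scatter), is large and lies beyond the scatter; it is a fluoro in place of hydrogen on an aromatic carbon. Compound 3 `O=S(=O)(/C=C/c1ccc(F)cc1F)Cc1ccc(Nc2ncnc3cc(Cl)ccc23)cc1` differs from compound 2 by another replacement, chloro in place of hydrogen on an aromatic carbon. For the measured compounds named here, no measured step tests this change directly, so the fluoro step offers only indirect guidance, showing that one such replacement can matter in this assay. Going by the values given here, with compound 1 at 5000 nM as the only exact number, a move toward stronger growth inhibition is expected, though its size is uncertain. The expected change is an at least 4.0-fold lower number from compound 2 to compound 3 (0.60 log units; beyond the scatter). Compound 3 is estimated at 25000 nM, with an expected range from 4000 nM to 100000 nM.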

Compound 3, concentration for 50% growth inhibition: > 100000 nM
Compound 3: no number, only a limit; the forecaster's own chance of this, stated with the estimate: 40%; at least 4.0-fold (0.60 log units) between middle value and limit.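

Among the compounds shown here, compound 2 and compound 3 both give only a limit of the assay, so no step between them can be read: the limit of > 100000 nM in this assay, at which 2 of the 3 values shown sit. The compounds shown leave open whether chloro in place of hydrogen on an aromatic carbon changes growth inhibition at all in this assay.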